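A 4-Methoxyphenyl Arm Replaces Propyl on the Chain Carbon

The source may hold more compounds than are shown below. What is called first, only, known or untested is meant among the compounds shown, and "the series" means these compounds.

Compound 2, `CCCCN1CCC(C(=O)Nc2cc(Cl)c(N)cc2OC)CC1`, is one of two compounds tested in a functional assay on the whole organism for antagonist activity, with Mus musculus as the target; a higher number here means that more compound is needed for the effect, a lower number that less compound is needed. In this assay compound 2 gives > 10 mg/kg, which is a limit of the assay rather than a number. Its companion, compound 1 `COc1cc(N)c(Cl)cc1NC(=O)C1CCN(Cc2ccccc2Cl)CC1`, differs only in having 2-chlorophenyl in place of propyl on a saturated chain carbon bound to an amine nitrogen in a ring. In this assay compound 1 gives > 4 mg/kg, likewise a limit. The step that the two limits leave unreadable from compound 1 to compound 2 cannot be sized because the limit of > 10 mg/kg in this assay, at which 1 of the 2 values shown sits, and the limit of > 4 mg/kg in this assay, at which 1 of the 2 values shown sits, are both limits. Compound 3, `COc1ccc(CN2CCC(C(=O)Nc3cc(Cl)c(N)cc3OC)CC2)cc1`, carries the change (4-methoxyphenyl in place of propyl on a saturated chain carbon bound to an amine nitrogen in a ring). Among the measured compounds shown here, the sole measured step that bears on this change is that unreadable one, so neither a direction nor a size in this assay can be drawn from it, and a further limit is the most probable outcome. Compound 3 is therefore expected at 10 mg/kg, between 3 mg/kg and 30 mg/kg, an estimated step of a number no higher from compound 2 to compound 3 (the limit leaves the size open).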

Compound 3, dose for half-maximal effect: 0.9 mg/kg
Compound 3: the middle estimate sits 11-fold (1.05 log units) above what was measured; measured number outside the range, below it.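

Compound 3 is the only one of the three with a number rather than a limit in this assay, so this place, a saturated chain carbon bound to an amine nitrogen in a ring, now shows that the arm can change the dose needed: the change from propyl gives an at least 11-fold lower number from compound 2 to compound 3 (1.04 log units; beyond the scatter), and the change from 2-chlorophenyl gives an at least 4.4-fold lower number from compound 1 to compound 3 (0.64 log units; beyond the scatter). Both 2-chlorophenyl and 4-methoxyphenyl carry an aromatic ring, yet they are separated by a step beyond the scatter, so the ring alone does not settle the outcome. The step from propyl is only a minimum, because compound 2 stands at a limit of the assay: the limit of > 10 mg/kg in this assay, at which 1 of the 3 values shown sits.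

From the compounds shown here alone, the full distance from 2-chlorophenyl also stays open, because compound 1 likewise stands at a limit: the limit of > 4 mg/kg in this assay, at which 1 of the 3 values shown sits. Whether the methoxy group or its place on the ring matters remains open, as does what an unsubstituted phenyl or a 4-chlorophenyl arm would give.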